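The source may hold more compounds than are shown below. What is called first, only, known or untested is meant among the compounds shown, and "the series" means these compounds.

Measured compounds in this series:

compound 1, `O=C(Nc1ccc(Oc2ccnc3[nH]ccc23)cc1)c1nn(-c2ccc(Cl)c(F)c2)ccc1=O`: 2580 nM
compound 2, `O=C(Nc1ccc(Oc2ccnc3[nH]ccc23)cc1)c1nn(-c2ccc(Cl)c(C(F)(F)F)c2)ccc1=O`: 2190 nM
compound 3, `O=C(Nc1ccc(Oc2ccnc3[nH]ccc23)c(F)c1)c1nn(-c2ccc(Cl)c(F)c2)ccc1=O`: 10300 nM

All three numbers come from a functional assay on A549 cells (Homo sapiens) for cytotoxicity, read by MTT assay, with a stated time of 72 h; a lower number here means a stronger inhibitor, a higher number a weaker inhibitor. Compound 2 differs from compound 1 in one place, (trifluoromethyl in place of fluoro on an aromatic carbon), and the step is a 1.2-fold lower number from compound 1 to compound 2 (0.07 log units; within the scatter). Compound 3 differs from compound 1 in the other part of the molecule, (fluoro in place of hydrogen on an aromatic carbon), and here the step is a 4.0-fold higher number from compound 1 to compound 3 (0.60 log units; beyond the scatter), so compound 3 stands with the highest number of the three. Among the measured compounds shown here, no single-point step connects compound 2 and compound 3; compound 2 gives 2190 nM whereas compound 3 gives 10300 nM.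

Compound 4, `O=C(Nc1ccc(Oc2ccnc3[nH]ccc23)c(F)c1)c1nn(-c2ccc(Cl)c(C(F)(F)F)c2)ccc1=O`, has not been measured. It differs from compound 3 by trifluoromethyl in place of fluoro on an aromatic carbon. The surroundings of the exchanged group read the same, word for word, as in the change from compound 1 to compound 2, so this is the same change made on the core of compound 3 rather than on the core of compound 1. For the measured compounds named here, the expectation for the step from compound 3 to compound 4 in this assay is a 1.2-fold lower number from compound 3 to compound 4 (0.08 log units; within the scatter), because the one earlier instance of this change gave a 1.2-fold lower number from compound 1 to compound 2 (0.07 log units; within the scatter), a step that does not rise above the scatter. This rests on a single prior pair, so the range is kept wide. Compound 4 is therefore estimated at 8500 nM, with a likely range from 4000 nM to 20000 nM.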

Compound 4, half-maximal inhibitory concentration: 13400 nM
For compound 4 the middle estimate is 1.6-fold (0.20 log units) below the measured one; the measured number falls inside the stated range.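

In this assay, trifluoromethyl in place of fluoro, the change from 4-chloro-3-fluorophenyl to 4-chloro-3-(trifluoromethyl)phenyl, gives a 1.3-fold higher number from compound 3 to compound 4 (0.11 log units; within the scatter), and this near-silent step carries from one core to the other without a difference beyond the scatter: the same change on two cores in this assay, a 1.2-fold lower number (0.07 log units; within the scatter) from compound 1 to compound 2 and a 1.3-fold higher number (0.11 log units; within the scatter) from compound 3 to compound 4, 1.5-fold (0.19 log units) apart, within the scatter of two such steps. Fluoro in place of hydrogen on the other part of the molecule, read on the trifluoromethyl compounds, gives a 6.1-fold higher number from compound 2 to compound 4 (0.79 log units; beyond the scatter), so the rise in the number seen with this fluoro also holds on both cores: the same change on two cores in this assay, a 4.0-fold higher number (0.60 log units; beyond the scatter) from compound 1 to compound 3 and a 6.1-fold higher number (0.79 log units; beyond the scatter) from compound 2 to compound 4, 1.5-fold (0.19 log units) apart, within the scatter of two such steps. Within these four compounds the two changes therefore read as independent of each other, but this rests on a single pair of cores for each change, and it shows neither that the same holds for other substituents nor why the added fluoro raises the number.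

The compounds shown leave open whether a group other than fluoro or trifluoromethyl, such as a nitrile, a methoxy or an amine, would stay as silent in place of the exchanged group. They also leave open whether methyl or chloro in place of the hydrogen that fluoro replaced would raise the number in the same way.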